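The compounds below may be only part of what the source reports. "The series", "measured", "known", "first", "only" and "open" are said of these compounds alone.

Series notes, shared core carrying the azetidinylmethoxy side chain with a pyridyl ring on the chlorinated ring. In an assay on membranes from brain with Neuronal acetylcholine receptor; alpha4/beta2 (Rattus norvegicus) as the target (on this read-out higher numbers stand for weaker inhibition and lower numbers for stronger inhibition), compound 1 `Clc1ncc(OC[C@@H]2CCN2)cc1-c1cccnc1` gives 0.0081 nM. Compound 2 `Ic1ncc(OC[C@@H]2CCN2)cc1-c1cccnc1` gives 0.0117 nM in this assay; the step of a 1.4-fold higher number from compound 1 to compound 2 (0.16 log units; within the scatter) swaps iodo for chloro on an aromatic carbon and stays inside the noise. Among the compounds with values here, compound 3 `Fc1ccc(-c2cc(OC[C@@H]3CCN3)cnc2Cl)cn1` gives 0.0049 nM in this assay, the lowest of the three numbers so far, though its nearest neighbour compound 1 sits within the scatter and only compound 2 lies beyond it. The step of a 1.7-fold lower number from compound 1 to compound 3 (0.22 log units; within the scatter) brings in fluoro for hydrogen on an aromatic carbon, again without leaving the noise.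

Compound 4 `Clc1ccc(-c2cc(OC[C@@H]3CCN3)cnc2Cl)cn1` is not yet measured in this assay. It differs from compound 3 by chloro in place of fluoro on an aromatic carbon, placed on an aromatic carbon of a six-membered aromatic ring with one nitrogen, next to the ring nitrogen and para to a large group. Both recorded steps bear on it: each exchanges one halogen-type substituent on an aromatic carbon, and each stayed within the scatter. A halogen-for-halogen swap at the fluoro position is therefore expected to move this assay by no more than the scatter, in no fixed direction, so the estimate for compound 4 is 0.0055 nM, ranging from 0.0022 nM to 0.014 nM, which would mean a step of a 1.1-fold higher number from compound 3 to compound 4 (0.05 log units; within the scatter) expected to be within the noise.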

Compound 4, inhibition constant: 0.0045 nM
Compound 4: middle estimate off by 1.2-fold (0.09 log units), on the high side; measured number inside the range.
By their numbers in this assay, from the lowest: compounds 4, 3, 1 and 2 (each within the scatter of the next, the first and the last beyond it).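

In this assay, exchanging fluoro for chloro on the aromatic carbon next to the ring nitrogen and para to a large group gives a 1.1-fold lower number from compound 3 to compound 4 (0.04 log units; within the scatter), so the two halogens cannot be told apart at this position. Against hydrogen at the same position, chloro gives a 1.8-fold lower number from compound 1 to compound 4 (0.26 log units; within the scatter), and fluoro had given a 1.7-fold lower number from compound 1 to compound 3 (0.22 log units; within the scatter), so the series now holds two halogens here and neither step leaves the scatter. Nothing on hand accounts for this flat response.

The compounds shown leave open whether the flat response extends beyond small halogens at this position: an amine, a methoxy group, a nitrile or a carboxylic acid could still move the number beyond the scatter, and a bromo or iodo group here would show whether halogen size matters at all. Also open, as far as these compounds go, is whether the response stays flat when one of these groups is combined with a group other than chloro or iodo on the chlorinated ring of the shared core.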